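Biguanides on bladder cancer cells: heptyl to cyclopentyl

This account rests on a few compounds, and the source may have more. Where it says the series, first, only, none or still open, it means among the compounds named here.

Three biguanides carrying a fluorinated aryl group have been measured so far. Compound 1 `CCCCCCCNC(=N)NC(=N)Nc1ccc(F)c(F)c1` gives 2100 nM in a functional assay on UMUC3 cells (Homo sapiens) for antiproliferative activity, read by MTT assay, with a stated time of 72 h (a higher number here means a weaker inhibitor, a lower number a stronger inhibitor), the second highest of the three numbers. Compound 2 `CC(C)CNC(=N)NC(=N)Nc1ccc(C(F)(F)F)cc1` gives 2000 nM, within the scatter of compound 1, while compound 3 `CCN(CC)C(=N)NC(=N)Nc1ccc(C(F)(F)F)cc1` gives 4900 nM, beyond the scatter from compound 1. For the measured compounds named here, the only step that changes the group on the amine nitrogen is a 2.5-fold higher number from compound 2 to compound 3 (0.39 log units; beyond the scatter), a modest weakening.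

Compound 4 `N=C(NC(=N)NC1CCCC1)Nc1ccc(F)c(F)c1` differs from compound 1 by cyclopentyl in place of heptyl on an amine nitrogen. Going by the values given here, the one measured step touching that position is modest, and the change in compound 4 keeps an alkyl amine, so he expects at most a small move, likely toward a somewhat higher number or none beyond the scatter. He estimates for compound 4 a value of 2800 nM, with a range from 1200 nM to 6500 nM, which would be a step of a 1.3-fold higher number from compound 1 to compound 4 (0.12 log units; within the scatter).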

Compound 4, half-maximal inhibitory concentration: 7200 nM
Compound 4: the middle estimate sits 2.6-fold (0.41 log units) below what was measured, outside the stated range (above it).
By their numbers in this assay, from the lowest: compounds 2 and 1 (each within the scatter of the next); then compounds 3 and 4 (each within the scatter of the next).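

Cyclopentyl in place of heptyl gives a 3.4-fold higher number from compound 1 to compound 4 (0.54 log units; beyond the scatter) in this assay, so with the rest of compound 1 unchanged, the group on this amine nitrogen alone moves the number beyond the scatter. This is a second modest step at this kind of position, alongside a 2.5-fold higher number from compound 2 to compound 3 (0.39 log units; beyond the scatter) on a different aryl group, and both run toward a higher number. The change swaps an open chain of 7 carbons for a ring of 5 carbons, and no measurement here offers an explanation for the step.

Going by these compounds, whether the ring or the shorter carbon count matters more stays open, and an open pentyl chain on the same core would separate the two. Also open, on these data alone, is how a cyclohexyl group or a longer chain such as octyl would behave at this position.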